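From pyrazin-2-yl to 2-chloro-6-methylpyridin-3-yl on the shared core

The source may hold more compounds than are shown below. What is called first, only, known or untested is meant among the compounds shown, and "the series" means these compounds.

Compound 2 `O=[N+]([O-])c1cc(-c2cc(-c3cnccn3)no2)cc(O)c1O` stands highest of the two measured compounds in a functional assay on the whole organism (liver, strain NMRI) for inhibition, with Mus musculus as the target, with a stated time of 3 h, at a dose of 3 mg/kg by the oral route (a higher number here means more inhibition at the dose given (going by the name of the read-out), a lower number less inhibition), giving 44.7%. Compound 1 `O=[N+]([O-])c1cc(-c2cc(-c3ccncc3)no2)cc(O)c1O` gives 32.1%, and the step was a number 12.6 percentage points higher from compound 1 to compound 2 (beyond the scatter). Compound 3 `Cc1ccc(-c2cc(-c3cc(O)c(O)c([N+](=O)[O-])c3)on2)c(Cl)n1` differs from compound 2 by 2-chloro-6-methylpyridin-3-yl in place of pyrazin-2-yl on an aromatic carbon. For the measured compounds named here, only that single measured step bears on the change, and it concerned a different ring; the entering arm carries a chlorine and a methyl for which no measured step exists. A modest fall is therefore expected, a number 6.7 percentage points lower from compound 2 to compound 3 (within the scatter), within wide bounds. Compound 3 is estimated at 38% in this assay, expected to range from 18% to 60%.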

Compound 3, a percentage reported as inhibition, in the whole organism at one dose (the size of the read-out at that dose, not a potency): 21.6%
Estimate against measurement, compound 3: 16.4 percentage points above; the range from low to high includes it.
By their numbers in this assay, from the lowest: compound 3; then compound 1; then compound 2.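

At this position, next to the ring nitrogen, the 2-chloro-6-methylpyridin-3-yl arm gives the lowest number of the three in this assay with a number 23.1 percentage points lower from compound 2 to compound 3 (beyond the scatter) and a number 10.5 percentage points lower from compound 1 to compound 3 (beyond the scatter) as its two steps. Six-membered aromatic arms are thus not interchangeable here, and the order now runs from this arm through pyridin-4-yl to pyrazin-2-yl. No evidence is available to explain this result. The chlorine and the methyl enter together, so the compounds shown do not separate them. On these data alone, how an amine at this position would read in this assay also stays open.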